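The compounds below may be only part of what the source reports. "The series", "measured", "known", "first", "only" and "open" are said of these compounds alone.

Measured compounds:
compound 1 `COc1ccc(-c2ccc(C(=O)Nc3ccc(Oc4ccnc5[nH]ccc45)c(F)c3)nc2)cc1` — 10100 nM
compound 2 `O=C(Nc1ccc(Oc2ccnc3[nH]ccc23)c(F)c1)c1ccc(-c2ccc(F)cc2)cn1` — > 10000 nM
compound 3 `COc1ccc(-c2ccnc(C(=O)Nc3ccc(Oc4ccnc5[nH]ccc45)c(F)c3)c2)cc1` — 9110 nM

In a functional assay on MCF7 cells (Homo sapiens) for cytotoxicity, read by MTT assay, with a stated time of 72 h (on this read-out lower numbers stand for stronger inhibition and higher numbers for weaker inhibition), compound 1 gives 10100 nM. For compound 2 the assay reports only a limit, > 10000 nM. The step that the limit leaves unreadable from compound 1 to compound 2 is fluoro in place of methoxy on an aromatic carbon; its size cannot be read because of the limit of > 10000 nM in this assay, at which 1 of the 3 values shown sits. Compound 3 gives 9110 nM, within the scatter of compound 1. The difference between the core of compound 1 and the core of compound 3 is not broken down here.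

Compound 4 `O=C(Nc1ccc(Oc2ccnc3[nH]ccc23)c(F)c1)c1cc(-c2ccc(F)cc2)ccn1` is not yet measured. It carries fluoro in place of methoxy on an aromatic carbon, the same change as from compound 1 to compound 2, at a place described in the same words. Given that the earlier step ran into the limit from a starting point like that of compound 3, the step of a 1.4-fold higher number from compound 3 to compound 4 (0.15 log units; within the scatter) is expected to be small or toward weaker inhibition, and a reported limit is likely. Compound 4 is estimated at 13000 nM, between 6000 nM and 30000 nM.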

Compound 4, half-maximal inhibitory concentration: 9520 nM
For compound 4 the middle estimate is 1.4-fold (0.14 log units) above the measured one, and the stated range covers the measured number.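

In this assay, fluoro in place of methoxy on the core of compound 3 gives a 1.0-fold higher number from compound 3 to compound 4 (0.02 log units; within the scatter), so on this core the change leaves the number within the scatter. Compound 2 gives > 10000 nM, which is a limit and not a number. The same change on the core of compound 1 therefore cannot be read, and the two cores cannot be compared for it, so carrying the change from one core to the other is shown on one side only: the limit of > 10000 nM in this assay, at which 1 of the 4 values shown sits.

Only methoxy and fluoro appear on this aromatic ring. From the compounds shown here alone, whether an amine, a carboxylic acid or a longer chain in their place would give a lower number in this assay stays open.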